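The source may report more compounds than this note shows. Statements on the series, on what has been measured and on what is new or still open speak of the compounds shown alone.

Compound 1 (`C=CCCCCOc1cc(F)ccc1-c1cnc(OCCC=C)n1C`) gives 64000 nM
Compound 2 (`C#CCCCCOc1ncc(-c2ccccc2OC)n1C`) gives 21000 nM

Both numbers come from a functional assay on PC-3 cells (Homo sapiens) for inhibition, read by colorimetric assay and MTT assay, with a stated time of 72 h (a lower number here means a stronger inhibitor, a higher number a weaker inhibitor), and compound 2 holds the lower one, a gap from compound 1 that lies beyond the usual scatter. Compound 3 (`COc1ccccc1-c1cnc(OCCCc2ccccc2)n1C`) has not yet been measured. It differs from compound 2 by one change (phenyl in place of propargyl on a saturated chain carbon, three bonds along the chain from an oxygen on an aromatic ring): phenyl in place of propargyl on a saturated chain carbon, three bonds along the chain from an oxygen on an aromatic ring. Within the data shown here, no measured pair shows this kind of change, so the expectation is loose. An estimated 1.4-fold lower number from compound 2 to compound 3 (0.15 log units; within the scatter) is expected, pointing slightly toward a stronger inhibitor but not beyond the scatter. Compound 3 is expected to read 15000 nM (range 5000 nM to 45000 nM).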

Compound 3, half-maximal inhibitory concentration: 27000 nM
The estimate for compound 3 lay 1.8-fold (0.26 log units) below the measured number; measured number inside the range.
By their numbers in this assay, from the lowest: compounds 2 and 3 (each within the scatter of the next); then compound 1.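

Among these compounds, replacing propargyl with phenyl on a saturated chain carbon, three bonds along the chain from an oxygen on an aromatic ring, gives a 1.3-fold higher number from compound 2 to compound 3 (0.11 log units; within the scatter) in this assay, the first direct comparison at this position. A six-membered aromatic ring of carbon only can therefore stand where the smaller triple-bonded group stood without a readable shift in the number. No supporting measurement explains this result. Still open, from the compounds shown here alone, is whether an amine or a carboxylic acid at this chain end would shift the number beyond the scatter, and whether a longer chain carrying the phenyl would do so.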